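A few compounds are considered here, and "the series" means these few. Any claim that something is new, unique, unknown or untested is made for them only; others in the source may bear on it.

Compound 1 `O=C(NCc1cn(Cc2ccc(C(F)(F)F)cc2)nn1)c1cn(-c2ccccc2)nc1-c1ccccc1`: 1600 nM. Compound 2 `COc1cc(Cn2cc(CNC(=O)c3cn(-c4ccccc4)nc3-c3ccccc3)nn2)cc(OC)c1`: 12200 nM.

In a functional assay on HeLa cells (Homo sapiens) for antiproliferative activity, read by sulforhodamine B assay, with a stated time of 48 h (a lower number here means a stronger inhibitor of growth, a higher number a weaker inhibitor of growth), compound 1 stands lowest of the two numbers; the nearest is compound 2, with a 7.6-fold higher number from compound 1 to compound 2 (0.88 log units; beyond the scatter). Compound 3 `O=C(NCc1cn(Cc2ccc(C(F)(F)F)cc2)nn1)c1cn(-c2ccccc2)nc1-c1ccc(Cl)cc1` differs from compound 1 by chloro in place of hydrogen on an aromatic carbon, on an aromatic carbon of a six-membered aromatic ring of carbon only, para to a large group; cut one bond further out, phenyl becomes 4-chlorophenyl. Within the data shown here, the single measured step alters the group on a saturated chain carbon bound to an aromatic nitrogen and leaves this ring untouched, so no measured step bears on the change. The expected step is accordingly none beyond the scatter, a 1.2-fold lower number from compound 1 to compound 3 (0.09 log units; within the scatter). Compound 3 is estimated at 1300 nM, within 450 nM to 4000 nM.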

Compound 3, concentration for 50% growth inhibition: 1900 nM
Compound 3: the middle estimate sits 1.5-fold (0.16 log units) below what was measured; low and high end bracket the measured number.
By their numbers in this assay, from the lowest: compounds 1 and 3 (each within the scatter of the next); then compound 2.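

In this assay, phenyl to 4-chlorophenyl gives a 1.2-fold higher number from compound 1 to compound 3 (0.07 log units; within the scatter), so a chlorine at this place, para to a large group, leaves the number within the scatter. Among these compounds, this is the first reading on this ring; the earlier step concerned only the group on the saturated chain carbon bound to an aromatic nitrogen. Nothing available gives a reason for this result.

Going by these compounds, whether a larger or hydrogen-bonding group here, such as methoxy or an amine, would also leave the number unchanged remains open. Also open, on these data alone, is whether chloro behaves alike with the 3,5-dimethoxyphenyl group of compound 2.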